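The compounds below may be only part of what the source reports. "The series", "measured", "known", "first", "only" and "open" are said of these compounds alone.

Measured so far in a functional assay on HT-29 cells (Homo sapiens) for antiproliferative activity, read by MTT assay, with a stated time of 24 h; a higher number here means a weaker inhibitor, a lower number a stronger inhibitor:

- compound 1, `COc1ccc(C(=O)/C=C/c2ccc(Br)cc2)c2c1C=CC(C)(C)O2`: > 10000 nM
- compound 2, `COc1ccc(C(=O)/C=C/c2ccc(-c3ccccc3)cc2)c2c1C=CC(C)(C)O2`: > 10000 nM
- compound 3, `COc1ccc(C(=O)/C=C/c2ccc(-n3ccnc3)cc2)c2c1C=CC(C)(C)O2`: > 6600 nM

Compound 1 gives only a limit of this assay in > 10000 nM, not a number. Compound 2 likewise sits at a limit, > 10000 nM. Compound 3 also returns a limit, > 6600 nM. The steps between them are accordingly not readable: a step that the two limits leave unreadable from compound 1 to compound 2, a step that the two limits leave unreadable from compound 1 to compound 3 and a step that the two limits leave unreadable from compound 2 to compound 3. Two of the three values rest at the limit of > 10000 nM in this assay, at which 2 of the 3 values shown sit, the third at the limit of > 6600 nM in this assay, at which 1 of the 3 values shown sits.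

Compound 4, `COc1ccc(C(=O)/C=C/c2ccccn2)c2c1C=CC(C)(C)O2`, differs from compound 1 by pyridin-2-yl in place of 4-bromophenyl on a double-bonded chain carbon bound to a double-bonded chain carbon. Among the measured compounds shown here, none of the measured steps touches the ring attached to the double-bonded chain carbon itself; all three vary a substituent on that ring, and all end at a limit. For the measured compounds named here, there is therefore no measured step that bears on the change to compound 4, and no direction can be read from the series. Going by the values given here, with every value so far at a limit, compound 4 is expected to remain weak in this assay, most likely again as a limit, with an expected step that the limit leaves unreadable from compound 1 to compound 4. Compound 4 is estimated at 12000 nM, within a range of 3000 nM to 50000 nM.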

Compound 4, half-maximal inhibitory concentration: 2120 nM
Beside the measured number, compound 4's estimate is 5.7-fold (0.75 log units) above it; measured number outside the range, below it.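

In this assay, pyridin-2-yl in place of 4-bromophenyl on a double-bonded chain carbon bound to a double-bonded chain carbon gives an at least 4.7-fold lower number from compound 1 to compound 4 (0.67 log units; beyond the scatter). Exchanging the whole ring at this place therefore moves the read-out beyond the scatter, and compound 4 is the only compound shown with a number rather than a limit. The size of this step is only a minimum because compound 1 stands at a limit: the limit of > 10000 nM in this assay, at which 2 of the 4 values shown sit.

The compounds shown do not separate the effect of the ring nitrogen from that of losing the bromo substituent, and an unsubstituted phenyl at this place would address that. From the compounds shown here alone, whether the nitrogen's place in the ring matters stays open too, a question for pyridin-3-yl and pyridin-4-yl.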